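Compound 1's trimethoxyphenyl exchanged for methylphenyl

The source may report more compounds than this note shows. Statements on the series, on what has been measured and on what is new or still open speak of the compounds shown alone.

Compound 1 `COc1cc(-c2nc(SCc3cn(CC(=O)NC(=O)Nc4ccccn4)nn3)nc(Nc3ccc(C)cc3)c2C#N)cc(OC)c1OC` — 32 nM
Compound 2 `COc1cc(-c2nc(SCc3cn(CC(=O)NC(=O)Nc4ccccn4)nn3)nc(Nc3cccc(C(F)(F)F)c3)c2C#N)cc(OC)c1OC` — 24400 nM
Compound 3 `COc1cc(-c2nc(SCc3cn(CC(=O)NC(=O)Nc4ccccn4)nn3)nc(Nc3cccc(Cl)c3)c2C#N)cc(OC)c1OC` — 1420 nM

In a functional assay on B16-F10 cells (Mus musculus) for inhibition, read by MTT assay, with a stated time of 72 h (a higher number here means a weaker inhibitor, a lower number a stronger inhibitor), compound 1 gives 32 nM, the lowest of the three numbers. Compound 3 gives 1420 nM and compound 2 gives 24400 nM. The three measured steps all change the group on the nitrogen of the shared core: a 44-fold higher number from compound 1 to compound 3 (1.65 log units; beyond the scatter), a 760-fold higher number from compound 1 to compound 2 (2.88 log units; beyond the scatter) and a 17-fold lower number from compound 2 to compound 3 (1.24 log units; beyond the scatter). Every one of them is large and beyond the scatter, and every one leaves the trimethoxyphenyl untouched.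

Compound 4 `Cc1ccc(Nc2nc(SCc3cn(CC(=O)NC(=O)Nc4ccccn4)nn3)nc(-c3ccc(C)cc3)c2C#N)cc1` changes a different position: 4-methylphenyl in place of 3,4,5-trimethoxyphenyl on an aromatic carbon. For the measured compounds named here, none of the measured steps bears on this position, so the record gives no direct guide to its size or direction. What the record does show is that the shared core is sensitive to changes at an aryl substituent, with large shifts from a single exchange. On that basis the account expects a sizeable rise in the number, but with wide uncertainty. Compound 4 is estimated at 500 nM, between 40 nM and 8000 nM, which means an expected step of a 16-fold higher number from compound 1 to compound 4 (1.19 log units; beyond the scatter).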

Compound 4, half-maximal inhibitory concentration: 1010 nM
The estimate for compound 4 lay 2.0-fold (0.31 log units) below the measured number; the measured number falls inside the stated range.
By their numbers in this assay, from the lowest: compound 1; then compounds 4 and 3 (each within the scatter of the next); then compound 2.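

In this assay the exchange at this aromatic carbon gives a 32-fold higher number from compound 1 to compound 4 (1.50 log units; beyond the scatter), so the earlier finding of large shifts from changes on the nitrogen now extends to a second position on the shared core. For the compounds shown here, with the 4-methylphenyl on the nitrogen held constant, this pair gives the first direct reading at this position, and the lower number belongs to 3,4,5-trimethoxyphenyl rather than 4-methylphenyl. Going by these compounds alone, the single step replaces a group of 12 heavy atoms and 3 hydrogen-bond acceptors with one of 7 heavy atoms and 0 hydrogen-bond acceptors, and nothing available explains why the number rises.

The compounds shown leave open whether the rise tracks all three methoxy groups together or only one of them, a question that 4-methoxyphenyl or 3,5-dimethoxyphenyl at this carbon could help to separate. They also leave open whether unsubstituted phenyl would behave like 4-methylphenyl here, and whether the step would keep its size with 3-chlorophenyl rather than 4-methylphenyl on the nitrogen.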